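Replacing the Chloropyridine of Compound 1

This account rests on a few compounds, and the source may have more. Where it says the series, first, only, none or still open, it means among the compounds named here.

Among the measured compounds shown here, compound 1 (`Cc1nc(C)c(C(=O)Nc2ccc(F)c(-c3nc4ncc(-c5cccnc5Cl)cn4n3)c2)o1`) is one of only two compounds with a reading in a physicochemical assay for solubility, read by LC-MS, at pH 2, tested at 50 uM; a lower number here means a less soluble compound, a higher number a more soluble compound. In this measurement compound 1 gives 4080 nM, the lower of the two numbers, and its distance from the other lies beyond the usual scatter. The other, compound 2 (`O=C(Nc1ccc(F)c(-c2nc3ncc(-c4cccnc4F)cc3[nH]2)c1)N1CCCC1`), gives 43100 nM. Compound 2 differs from compound 1 in more than one place, so the pair isolates no single change.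

Compound 3 (`Cc1nc(C)c(C(=O)Nc2ccc(F)c(-c3nc4ncc(-c5ccccc5Cl)cn4n3)c2)o1`), not yet measured, carries 2-chlorophenyl in place of 2-chloropyridin-3-yl on an aromatic carbon. For the measured compounds named here, no measured pair shows this exchange, so the expectation rests on the structural change alone, in which the entering group has no hydrogen-bond acceptor. In this assay, a downward step of moderate size is expected, a little beyond the scatter, though a result within it would not be surprising. The estimated change is a 2.3-fold lower number from compound 1 to compound 3 (0.36 log units; beyond the scatter). Compound 3 is expected to give 1800 nM, with an estimated range of 500 nM to 5500 nM.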

Compound 3, solubility: 1800 nM
Estimate against measurement, compound 3: no gap at the digits printed, within the range that was stated.
By their numbers in this assay, from the lowest: compound 3; then compound 1; then compound 2.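

Among the compounds shown here, exchanging the 2-chloropyridin-3-yl of compound 1 for 2-chlorophenyl gives the first comparison in this assay that isolates a single change, with a 2.3-fold lower number from compound 1 to compound 3 (0.36 log units; beyond the scatter) at this position on the shared core. The step is modest, but it lies beyond the usual scatter, so the swap between these two groups, which differ in the ring nitrogen and in the single hydrogen-bond acceptor counted for the leaving group, does register in this read-out, and compound 3 now has the lowest number of the three. No measured property bears on why the number falls, so the step stands as an observation only.

The compounds shown cover only these two chlorine-bearing aromatic groups at this position, and compound 2 differs from both compound 1 and compound 3 in more than one place, so it cannot extend the comparison. As far as these compounds go, it remains open how this assay would respond to a morpholine, a primary amine or a carboxylic acid at this position, and whether the step seen here would recur on a different core.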